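The source may hold more compounds than are shown below. What is called first, only, known or untested is meant among the compounds shown, and "the series" means these compounds.

Measured in a functional assay on MDA-MB-231 cells (Homo sapiens) for cytotoxicity, read by MTT assay, with a stated time of 72 h; on this read-out higher numbers stand for weaker inhibition and lower numbers for stronger inhibition:
- compound 1 `Cc1ccc(F)cc1NC(=O)CN1CCN(c2nnc(Cc3ccccc3)c3ccccc23)CC1`: 19200 nM
- compound 2 `O=C(CN1CCN(c2nnc(Cc3ccccc3)c3ccccc23)CC1)Nc1cccc(F)c1`: 3730 nM

Compound 2, at 3730 nM, has the lower of the two numbers, so it is the stronger inhibitor of this pair. Compound 3 `O=C(CN1CCN(c2nnc(Cc3ccccc3)c3ccccc23)CC1)Nc1cccc(Br)c1` differs from compound 2 in one place: bromo in place of fluoro on an aromatic carbon. This is bromo in place of fluoro on an aromatic carbon, meta to a large group. For the measured compounds named here, only one measured step offers any guidance: a 5.1-fold lower number from compound 1 to compound 2 (0.71 log units; beyond the scatter), which is hydrogen in place of methyl on an aromatic carbon. That modest step shows that a single small swap can move the number beyond the scatter. However, it involves a different group, and no measured pair exchanges one halogen for another, so it gives no direction. A step smaller than that one is therefore expected, possibly within the scatter. The expected change is a 1.2-fold lower number from compound 2 to compound 3 (0.07 log units; within the scatter). The estimate for compound 3 is 3200 nM, with an expected range of 1300 nM to 8000 nM.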

Compound 3, half-maximal inhibitory concentration: 3880 nM
Estimate against measurement, compound 3: 1.2-fold (0.08 log units) below, within the range that was stated.
By their numbers in this assay, from the lowest: compounds 2 and 3 (each within the scatter of the next); then compound 1.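

In this assay, fluoro and bromo on this aromatic carbon, meta to a large group, cannot be told apart (a 1.0-fold higher number from compound 2 to compound 3 (0.02 log units; within the scatter)), so this exchange of one halogen for another leaves the number within the scatter. The lower number relative to compound 1 also holds with either halogen: the fluoro compound shows it (a 5.1-fold lower number from compound 1 to compound 2 (0.71 log units; beyond the scatter)), and the bromo compound shows it to a similar extent (a 4.9-fold lower number from compound 1 to compound 3 (0.69 log units; beyond the scatter)). Nothing available explains why the two halogens read alike.

The compounds shown do not reveal whether this flat result extends to chloro, the halogen missing from this pair, or to quite different groups at the same place, such as methoxy, an amine or a carboxylic acid. They also leave open whether any halogen is needed there at all.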